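One Double Bond Turned from E to Z

A few compounds are considered here, and "the series" means these few. Any claim that something is new, unique, unknown or untested is made for them only; others in the source may bear on it.

In a functional assay on A549 cells (Homo sapiens) for cytotoxicity (on this read-out lower numbers stand for an effect already at smaller amounts and higher numbers for an effect only at larger amounts of compound), compound 1 `C=C1OC(=O)/C(=C/CCCC/C=C\CCCCCCCCC)[C@@H]1O` gives 3.01 ug/mL as a measured number. Compound 2 `C=CCCCCCCCCC/C=C1/C(=O)OC(=C)[C@H]1O` is recorded at > 10 ug/mL and this is a limit of the assay, not a number. Compound 3 `C=CCCCCCCCCC/C=C1\C(=O)OC(=C)[C@H]1O` differs from compound 2 by a single change in configuration: the two compounds have the same atoms and bonds and differ only in configuration as drawn: 1 of 2 stereo elements differ; a double bond is drawn E in compound 2 and Z in compound 3 and nothing else is altered. Within the data shown here, no measured pair shows what such a change does, so the expected step of an at least 1.1-fold lower number from compound 2 to compound 3 (0.04 log units; that floor lies within the scatter) in this assay is small, within the usual scatter and without a firm direction. For compound 3 the estimated value is 9 ug/mL with an expected range from 3.5 ug/mL to 25 ug/mL and a report of only a limit would be no surprise.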

Compound 3, concentration for half-maximal effect: 3.32 ug/mL
The estimate for compound 3 lay 2.7-fold (0.43 log units) above the measured number, and the stated range ends above it.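

In this assay, turning the one double bond from E to Z gives an at least 3.0-fold lower number from compound 2 to compound 3 (0.47 log units; beyond the scatter). Compound 2 stands at a limit of the assay, so this step has a floor but no known size: the limit of > 10 ug/mL in this assay, at which 1 of the 3 values shown sits. Unlike compound 1, this pair isolates the double bond, and the shift can be assigned to its configuration alone: the fact that compounds 2 and 3 differ only in the configuration as drawn.

The compounds shown leave open whether the same change in configuration has a similar effect on a longer chain. They also leave open whether it would hold with an amine at the end of the chain.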